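The source may hold more compounds than are shown below. What is called first, only, known or untested is meant among the compounds shown, and "the series" means these compounds.

Compound 1 `O=C(Nc1cccc([N+](=O)[O-])c1)N[C@H]1CC[C@H](Oc2ccc(F)cc2)CC1` carries a 3-nitrophenyl group on one nitrogen of its urea linker. In a functional assay on CRL2813 cells (Homo sapiens) for cytotoxicity, read by sulforhodamine B assay, with a stated time of 5 days (a higher number here means a weaker inhibitor, a lower number a stronger inhibitor), compound 1 gives 6700 nM, the lowest of the two numbers measured here; its nearest neighbour is compound 2 `O=C(Nc1ccccc1F)N[C@H]1CC[C@H](Oc2ccc(F)cc2)CC1`, which gives 17500 nM, and the step of a 2.6-fold higher number from compound 1 to compound 2 (0.42 log units; beyond the scatter) lies beyond the scatter. Compound 3 `COc1ccc(NC(=O)N[C@H]2CC[C@H](Oc3ccc(F)cc3)CC2)cc1` reports only a limit in this assay, > 20000 nM, with the limit of > 20000 nM in this assay, at which 1 of the 3 values shown sits. The step of an at least 2.9-fold higher number from compound 1 to compound 3 (0.47 log units; beyond the scatter) is therefore at least modest, while an at least 1.1-fold higher number from compound 2 to compound 3 (0.05 log units; that floor lies within the scatter) cannot be separated from the scatter.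

Compound 4 `Cc1cccc(NC(=O)N[C@H]2CC[C@H](Oc3ccc(F)cc3)CC2)c1` is the next variation on compound 1: methyl in place of nitro on an aromatic carbon. Both measured steps that leave from compound 1 replace its 3-nitrophenyl with a differently substituted phenyl ring, and both gave higher numbers, one modest and one at least modest. The change to compound 4 is of the same kind, so a modest rise in this assay is expected rather than a drop, although the two earlier steps set no upper limit on how far such a change can move the number. Compound 4 is therefore estimated at 13000 nM, with a range from 5000 nM to 30000 nM. The expected step is a 1.9-fold higher number from compound 1 to compound 4 (0.29 log units; within the scatter).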

Compound 4, half-maximal inhibitory concentration: 14400 nM
The estimate for compound 4 lay 1.1-fold (0.04 log units) below the measured number; measured number inside the range.
By their numbers in this assay, from the lowest: compound 1; then compounds 4 and 2 (each within the scatter of the next). At a limit, above all of these: compound 3.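

Within the data shown here, compound 4 is the first pair in which the substituent stays meta to a large group and only its identity changes, and swapping nitro for methyl there still gives a 2.1-fold higher number from compound 1 to compound 4 (0.33 log units; beyond the scatter). The rise seen with the earlier ring changes therefore also appears with this simple swap at one place, and compound 1 keeps the lowest number of the set. By contrast, 3-methylphenyl and 2-fluorophenyl cannot be told apart in this assay, as a 1.2-fold lower number from compound 2 to compound 4 (0.08 log units; within the scatter) shows, while an at least 1.3-fold lower number from compound 3 to compound 4 (0.14 log units; that floor lies within the scatter) has a floor within the scatter and cannot be read as a real difference, since compound 3 gives only a limit and not a number: the limit of > 20000 nM in this assay, at which 1 of the 4 values shown sits.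

From the compounds shown here alone, what stays open is whether other groups at this place, such as an amine, a nitrile or a carboxylic acid, would keep the number near that of compound 1 or move it further. A single pair of nitro and methyl also cannot show which feature of the nitro group goes with the lower number, so no rule for this position follows from it.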